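A Methyl for a Methoxy on a Shared Core

This account rests on a few compounds, and the source may have more. Where it says the series, first, only, none or still open, it means among the compounds named here.

Measured compounds:
compound 1 `C=CCn1c(=O)/c(=C\c2ccc(Cl)c(Cl)c2)[nH]c(=O)/c1=C\c1ccccc1OC` — "not active" (no number reported) in a functional assay on K562 cells (Homo sapiens) for cytotoxicity, read by CCK-8 assay, with a stated time of 72 h; on this read-out higher numbers stand for weaker inhibition and lower numbers for stronger inhibition
compound 2 `C=CCn1c(=O)/c(=C\c2ccccc2OC)[nH]c(=O)/c1=C\c1ccccc1OC` — 7400 nM in this assay

Among the compounds with values here, compound 2 is the only compound with a number; compound 1 gave no number. Compound 3 `C=CCn1c(=O)/c(=C\c2ccc(C)cc2)[nH]c(=O)/c1=C\c1ccccc1OC` differs from compound 2 by 4-methylphenyl in place of 2-methoxyphenyl on a double-bonded chain carbon bound to an aromatic carbon. Within the data shown here, no step between measured compounds exists for guidance. Since compound 1, which also lacks the 2-methoxyphenyl at that place, gave "not active" (no number reported), the change is expected to weaken inhibition beyond the scatter, with a step of a 2.4-fold higher number from compound 2 to compound 3 (0.39 log units; beyond the scatter) estimated. Compound 3 is therefore expected to reach 18000 nM, in a range from 6000 nM to 60000 nM.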

Compound 3, half-maximal inhibitory concentration: "not active" (no number reported)
The entry for compound 3 holds no number, and the estimate cannot be compared.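

Within the data shown here, compound 3 gave "not active" (no number reported) and so no step from compound 2 can be read. On these data alone, how 4-methylphenyl compares numerically with 2-methoxyphenyl at that place stays open. No supporting evidence bears on this result.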